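Methoxy for Hydrogen: Estimating Compound 4

The compounds below may be only part of what the source reports. "The series", "measured", "known", "first", "only" and "open" are said of these compounds alone.

Compound 1 `O=C(Nc1ccccn1)c1cc2n(n1)CCCC2` is the reference here. Among the compounds with values here, in a functional assay on HEK293 cells for negative allosteric modulation of metabotropic glutamate receptor 5 (Rattus norvegicus), read by FLIPR and calcium flux, with a stated time of 170 s (on this read-out lower numbers stand for stronger inhibition and higher numbers for weaker inhibition), compound 1 gives 364 nM, the highest of the two numbers measured so far. Compound 3 `O=C(Nc1ccc(F)cn1)c1cc2n(n1)CCCC2` gives 60 nM, and the step of a 6.1-fold lower number from compound 1 to compound 3 (0.78 log units; beyond the scatter) lies beyond the scatter. Compound 2 `N#Cc1ccnc(NC(=O)c2cc3n(n2)CCCC3)c1` gives "not active" (no number reported). Compound 4 `COc1cccc(NC(=O)c2cc3n(n2)CCCC3)n1` differs from compound 1 by methoxy in place of hydrogen on an aromatic carbon. Within the data shown here, the only measured step that bears on this is the one from compound 1 to compound 3, yet it involves another group at another place, so it offers only loose guidance, and compound 2 shows that an added group can also remove any measurable number. For compound 4 the expected step is a 1.2-fold lower number from compound 1 to compound 4 (0.08 log units; within the scatter). The estimate for compound 4 is 300 nM, from 80 nM to 1200 nM.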

Compound 4, half-maximal inhibitory concentration: "not active" (no number reported)
Compound 4: no number reported; the estimate stays without a comparison.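

Within the data shown here, compound 4, like compound 2, has no reported number, so no step from compound 1 can be read, and no evidence here bears on this result. The compounds shown leave open whether methoxy elsewhere on the ring would give a measurable number.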